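A few compounds are considered here, and "the series" means these few. Any claim that something is new, unique, unknown or untested is made for them only; others in the source may bear on it.

Measured so far in a functional assay on A549 cells (Homo sapiens) for cytotoxicity, read by MTT assay, with a stated time of 48 h; on this read-out higher numbers stand for weaker inhibition and lower numbers for stronger inhibition:
- compound 1 `COc1cc(-c2nnc3n2NC(c2cccs2)C(C(=O)c2ccc(F)cc2)S3)cc(OC)c1OC` gives 45000 nM
- compound 3 `COc1cc(-c2nnc3n2NC(c2ccco2)C(C(=O)c2ccc(O)cc2)S3)cc(OC)c1OC` gives 93400 nM
- compound 2 `COc1cccc(C(=O)C2Sc3nnc(-c4cc(OC)c(OC)c(OC)c4)n3NC2c2ccco2)c1` gives > 100000 nM, which is a limit of this assay and not a number

Compound 1 stands lowest of the two numbers; the gap to compound 3 is beyond the usual scatter. Compound 2 sits at the limit of > 100000 nM in this assay, at which 1 of the 3 values shown sits.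

The new compound is compound 4 `COc1cc(C(=O)C2Sc3nnc(-c4cc(OC)c(OC)c(OC)c4)n3NC2c2cccs2)cc(OC)c1OC`. It differs from compound 1 in one place: 3,4,5-trimethoxyphenyl in place of 4-fluorophenyl on a carbonyl carbon. Among the measured compounds shown here, the only measured step that changes the group on the carbonyl carbon is an at least 1.0-fold lower number from compound 2 to compound 3 (0.02 log units; that floor lies within the scatter), and as it runs from a limit to a number it sets no real size. That step also swaps groups unlike those here, so nothing measured speaks directly to the change from compound 1 to compound 4. The expectation is therefore no step beyond the scatter, and the estimated step is a 1.2-fold higher number from compound 1 to compound 4 (0.09 log units; within the scatter). Compound 4 is thus expected to give about 55000 nM in this assay, within a range from 18000 nM to 150000 nM.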

Compound 4, half-maximal inhibitory concentration: > 100000 nM
Compound 4: a limit, no number; the forecaster's own chance of this, stated with the estimate: 30%; at least 1.8-fold (0.25 log units) between middle value and limit.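

In this assay, replacing 4-fluorophenyl with 3,4,5-trimethoxyphenyl on the carbonyl carbon gives an at least 2.2-fold higher number from compound 1 to compound 4 (0.34 log units; beyond the scatter). This shows that the result depends on the group at this position, which the earlier step on the same carbon could not show, as it ran from a limit to a number and stayed within the scatter. Compound 4 gives a limit and not a number, so this step is only a floor, and limits are not rare in this small set: the limit of > 100000 nM in this assay, at which 2 of the 4 values shown sit.

The compounds shown leave open whether the higher number goes with the three methoxy groups or with the loss of the fluorine. They also leave open how far the position tolerates other groups, and a plain phenyl or an amine-bearing phenyl on the same carbonyl carbon would help to separate these possibilities.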